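The source may report more compounds than this note shows. Statements on the series, on what has been measured and on what is new or still open speak of the compounds shown alone.

Working notes on the series. The shared core is that of compound 1 `Nc1cc(N)c2nc(-c3ccccc3)c(NCc3ccc(Cl)c(Cl)c3)nc2c1`, which in a functional assay on IGROV-1 cells (Homo sapiens) for inhibition, read by sulforhodamine B assay, with a stated time of 48 h (a lower number here means that less compound is tolerated, a higher number that more compound is tolerated), gives 29500 nM. Compound 2 `COc1ccc(CNc2nc3cc(N)cc(N)c3nc2-c2ccccc2)cc1OC` carries a 3,4-dimethoxyphenyl in place of the 3,4-dichlorophenyl of compound 1 on a saturated chain carbon bound to a nitrogen on an aromatic ring. In this assay compound 2 returns only a limit, < 100000 nM, and not a number. The step that the limit leaves unreadable from compound 1 to compound 2 is thus of unknown size; the limit of < 100000 nM in this assay, at which 1 of the 2 values shown sits, is what leaves it unreadable, so compound 2 stands on the numbers shown only as an undetermined edge.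

Compound 3 `COc1cc(CNc2nc3cc(N)cc(N)c3nc2-c2ccccc2)cc(OC)c1OC` differs from compound 2 by methoxy in place of hydrogen on an aromatic carbon. For the measured compounds named here, no measured step concerns adding a methoxy to an already methoxylated ring; the single step, from compound 1 to compound 2, bears on it only as an unreadable size. Going by the values given here, nothing here supports expecting a step beyond the scatter in this assay in either direction, so the estimate for compound 3 is expected to rest on the level of compound 1, 29500 nM, as the only readable number. Compound 3 is accordingly expected at 40000 nM, within 10000 nM to 100000 nM, an expected step that the limit leaves unreadable from compound 2 to compound 3.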

Compound 3, concentration lethal to 50% of the cells: < 50200 nM
Compound 3 was reported as a limit; the forecaster's own chance of this, stated with the estimate: 50%; the middle value is on the limit's open side.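

Compound 2 and compound 3 both return only limits in this assay, not numbers, and the step between them cannot be read. The compounds shown leave open whether methoxy in place of hydrogen on an aromatic carbon changes the value in this assay at all, and if so, in which direction and by how much.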